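Pyrazole acid series: cyanophenyl replacing fluorophenyl

The compounds below may be only part of what the source reports. "The series", "measured", "known", "first", "only" and "open" are said of these compounds alone.

Measured so far:
compound 1 `Cc1n[nH]c(C(=O)O)c1Cc1cccc(-c2cccc(F)c2)c1` — 20%
compound 2 `Cc1n[nH]c(C(=O)O)c1Cc1ccc(C(F)(F)F)cc1` — 9%

In an assay on isolated protein for inhibition of 2-Hydroxyacid oxidase 2 (Homo sapiens), tested at 1 uM (a higher number here means a stronger effect of the compound at the concentration tested, a lower number a weaker effect), compound 1 gives 20% and stands highest of the two numbers recorded. Its nearest neighbour is compound 2, which in this assay gives 9%; the gap between the two lies beyond the usual scatter of repeated measurements, so compound 1 is the stronger of the pair. Going by the values given here, the two compounds differ in more than one place, so no single structural step connects them and their values show only the ordering.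

Compound 3 `Cc1n[nH]c(C(=O)O)c1Cc1cccc(-c2ccc(C#N)cc2)c1` is the next compound to be measured. It differs from compound 1 in one place: 4-cyanophenyl in place of 3-fluorophenyl on an aromatic carbon

Among the compounds with values here, no step between measured compounds covers a change of this kind, so there is no recorded precedent to lean on. Both measured values are modest, and nothing in them points to a large move in either direction. The step is expected to be small, no change at the digits printed from compound 1 to compound 3 (within the scatter), and most likely none beyond the scatter. For compound 3 the expected value in this assay is 20%, with a range from 5% to 40%.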

Compound 3, a percentage reported as inhibition, at one concentration (the size of the read-out at that concentration, not a potency): 13%
Estimate against measurement, compound 3: 7 percentage points above; measured number inside the range.
By their numbers in this assay, from the lowest: compounds 2, 3 and 1 (each within the scatter of the next, the first and the last beyond it).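

In this assay, going by these compounds alone, 4-cyanophenyl in place of 3-fluorophenyl, on an aromatic carbon meta to a large group, gives a number 7 percentage points lower from compound 1 to compound 3 (within the scatter); this is the first single-place step, and its size cannot be told apart from repeat noise. The position therefore takes a nitrile-bearing phenyl, which carries a hydrogen-bond acceptor that 3-fluorophenyl lacks, with no resolved difference in the read-out, though a percentage at one concentration is not a potency. Nothing available explains the size of this step.

The names of the two groups show that the substituent and its place on the phenyl ring differ together, so this one step cannot assign any share of it to the swap of fluorine for nitrile or to the shift in place. Also open, as far as these compounds go, is whether a phenyl bearing an amine or a methoxy group at this position would give a step beyond the scatter in this assay, or whether the position stays flat across such groups.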